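Oxan-4-yl ether variant in the phenylpropanoic acid series

The source may report more compounds than this note shows. Statements on the series, on what has been measured and on what is new or still open speak of the compounds shown alone.

Measured so far:
compound 1 `COc1ccc(-c2c(C)cccc2C)cc1COc1ccc(CCC(=O)O)cc1` — "not determined" (no result reported)
compound 2 `COc1ccc(COc2ccc(CCC(=O)O)cc2)cc1-c1c(C)cccc1C` — 20 nM
compound 3 `CCOCCOc1cc(C)c(-c2cccc(COc3ccc(CCC(=O)O)c(F)c3)c2)c(C)c1` — 4.5 nM

In a functional assay on CHO cells for agonist activity at Free fatty acid receptor 1 (Homo sapiens), read by FLIPR and calcium flux, with a stated time of 90 s, in the presence of a further agent that is not named here (on this read-out lower numbers stand for an effect already at smaller amounts and higher numbers for an effect only at larger amounts of compound), compound 3 gives the lower of the two numbers reported; compound 2 sits higher, a gap beyond the usual scatter, and compound 1 carries no number. Compound 4 `Cc1cc(OC2CCOCC2)cc(C)c1-c1cccc(COc2ccc(CCC(=O)O)c(F)c2)c1` is the next entry: the change from compound 3 is oxan-4-yl in place of 2-ethoxyethyl on an oxygen on an aromatic ring. Among the compounds with values here, no pair of measured compounds spans this exchange, so there is no precedent to lean on. Both groups are ethers of comparable size with one acceptor each; the expected step from compound 3 to compound 4 is small, a 1.1-fold higher number from compound 3 to compound 4 (0.05 log units; within the scatter), and may not exceed the scatter. For compound 4 the estimate in this assay is 5 nM, within 2 nM to 15 nM.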

Compound 4, half-maximal effective concentration: 23 nM
The estimate for compound 4 lay 4.6-fold (0.66 log units) below the measured number; measured number above the stated range.
By their numbers in this assay, from the lowest: compound 3; then compounds 2 and 4 (each within the scatter of the next).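

In this assay the group on this oxygen on an aromatic ring is not freely exchangeable: oxan-4-yl in place of 2-ethoxyethyl gives a 5.1-fold higher number from compound 3 to compound 4 (0.71 log units; beyond the scatter) and lies beyond the scatter, although both groups count one hydrogen-bond acceptor and no donor. Within the data shown here, the open chain and the six-membered ring are therefore told apart at this position, which the earlier compounds could not show. Nothing available here accounts for the step.

Still open, from the compounds shown here alone, is whether the ring itself or its oxygen sets the step. Cyclohexyl or piperidin-4-yl on the same oxygen would separate the two.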